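The source may hold more compounds than are shown below. What is called first, only, known or untested is meant among the compounds shown, and "the series" means these compounds.

Compound 2 `Cc1nc2cnccc2n1CC1CCN(C(=O)CC(c2ccccc2)c2ccccc2)CC1` gives 7.6 nM in a functional assay (plasma) with Oryctolagus cuniculus as the target; a lower number here means a stronger inhibitor, a higher number a weaker inhibitor. Compound 1 `Cc1nc2cnccc2n1CC1CCN(C(=O)CC(C)c2ccccc2)CC1` is the same skeleton with methyl in place of phenyl on a saturated chain carbon bound to an aromatic carbon and a saturated chain carbon; in this assay compound 1 gives 12 nM, and the step is a 1.6-fold higher number from compound 2 to compound 1 (0.20 log units; within the scatter). Compound 3 `Cc1nc2cnccc2n1CC1CCN(C(=O)CC(O)(c2ccccc2)c2ccccc2)CC1` differs from compound 2 by hydroxy in place of hydrogen on a saturated chain carbon bound to two aromatic carbons and a saturated chain carbon; compound 3 gives 640 nM, and an 84-fold higher number from compound 2 to compound 3 (1.93 log units; beyond the scatter) is the largest step among these three.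

Compound 4 `Cc1nc2cnccc2n1CC1CCN(C(=O)CC(C)(O)c2ccccc2)CC1` is not yet measured. It differs from compound 3 by methyl in place of phenyl on a saturated chain carbon bound to an aromatic carbon, an oxygen on a saturated carbon and a saturated chain carbon, the same kind of change as that from compound 2 to compound 1, though here the place also carries an oxygen on a saturated carbon. Since the earlier step was a 1.6-fold higher number from compound 2 to compound 1 (0.20 log units; within the scatter), a similarly small step a 1.4-fold higher number from compound 3 to compound 4 (0.15 log units; within the scatter) is expected for compound 4. Compound 4 is therefore estimated at 900 nM in this assay, between 300 nM and 2700 nM.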

Compound 4, half-maximal inhibitory concentration: 6.9 nM
Estimate against measurement, compound 4: 130-fold (2.12 log units) above; measured number below the stated range.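

In this assay, methyl in place of phenyl gave a 93-fold lower number from compound 3 to compound 4 (1.97 log units; beyond the scatter), which does not match the same change on the core without the hydroxy: the same change on two cores in this assay, a 1.6-fold higher number (0.20 log units; within the scatter) from compound 2 to compound 1 and a 93-fold lower number (1.97 log units; beyond the scatter) from compound 3 to compound 4, 150-fold (2.17 log units) apart, beyond the scatter of two such steps. Hydroxy in place of hydrogen gave a 1.7-fold lower number from compound 1 to compound 4 (0.24 log units; within the scatter), so this change also failed to carry over from one core to the other: the same change on two cores in this assay, an 84-fold higher number (1.93 log units; beyond the scatter) from compound 2 to compound 3 and a 1.7-fold lower number (0.24 log units; within the scatter) from compound 1 to compound 4, 150-fold (2.17 log units) apart, beyond the scatter of two such steps. Together, these four compounds show that the size of either step depends on the other group at that carbon, but they do not show why, nor whether this holds beyond these compounds.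

On these data alone, it remains open whether a methoxy or an amine in place of the hydroxy would behave in the same way. The same question applies to an ethyl in place of the methyl.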